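The source may hold more compounds than are shown below. What is called first, only, known or untested is meant among the compounds shown, and "the series" means these compounds.

Compound 1 `O=C(CCCCCc1ccccc1)c1nc2cnccc2o1` gives 204 nM in an assay on HEK-293T cells for inhibition of diacylglycerol lipase-alpha (Homo sapiens), read by colorimetric assay; a lower number here means a stronger inhibitor, a higher number a weaker inhibitor.
Compound 2 `O=C(CCCCCCc1ccccc1)c1nc(C(=O)C(F)(F)F)co1` gives 123 nM in this assay.

Of these two numbers, compound 2 has the lower one, but compound 1 stands within the scatter of it, so no order between them can be read. Compound 3 `O=C(CCCCCCc1ccccc1)c1nc(-c2ccccc2)co1` arises from compound 2 by a single change: phenyl in place of (trifluoromethyl)carbonyl on an aromatic carbon. Going by the values given here, no pair of measured compounds shows the effect of such a change, so the expectation rests on the structures alone. Compound 3 is expected to give a weaker inhibitor, with the step of a 12-fold higher number from compound 2 to compound 3 (1.09 log units; beyond the scatter) estimated to lie beyond the scatter. Compound 3 is estimated at 1500 nM, expected between 300 nM and 8000 nM.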

Compound 3, half-maximal inhibitory concentration: 8710 nM
For compound 3 the middle estimate is 5.8-fold (0.76 log units) below the measured one, outside the stated range (above it).
By their numbers in this assay, from the lowest: compounds 2 and 1 (each within the scatter of the next); then compound 3.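

In this assay, this aromatic carbon next to the ring nitrogen proves sensitive to which group it carries: phenyl in place of (trifluoromethyl)carbonyl gives a 71-fold higher number from compound 2 to compound 3 (1.85 log units; beyond the scatter) and so a large loss. Size in heavy atoms alone does not set the number, since both groups count the same, while the change also removes a hydrogen-bond acceptor and a double bond. Nothing shown explains the step.

Going by these compounds, whether a nitrile, a methyl ester or a carboxylic acid at this carbon would keep the number of compound 2 stays open. So does whether an acetyl group, lacking the fluorines, would.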